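A few compounds are considered here, and "the series" means these few. Any claim that something is new, unique, unknown or untested is made for them only; others in the source may bear on it.

Measured so far:
compound 1 `O=C(O)c1cncc(CN2CCC[C@H](O[C@H](CO)c3cc(Cl)cc(Cl)c3)[C@@H]2c2ccccc2)c1` — 34000 nM
compound 2 `COC(=O)Nn1c(C[C@H]2CCC[C@H](OCc3cc(C(F)(F)F)cc(C(F)(F)F)c3)[C@@H]2c2ccccc2)n[nH]c1=O` — 4500 nM

Both numbers come from an assay on isolated protein for activation of cGMP-dependent protein kinase 1 (Homo sapiens), read by ADP-Glo, with stated times of 120 min and 40 min; a higher number here means that more compound is needed for the effect, a lower number that less compound is needed. Among the compounds with values here, compound 1 holds the highest number of the two; its only neighbour is compound 2, whose number is lower by an amount beyond the usual scatter. Within the data shown here, no pair of measured compounds differs in a single place, so the two values show only that the core of compound 2 reaches a lower number than the core of compound 1; no step can be carried over from them.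

Compound 3 `O=C(O)c1ccc2c(CN3CCC[C@H](O[C@H](CO)c4cc(Cl)cc(Cl)c4)[C@@H]3c3ccccc3)c[nH]c2c1` is not yet measured. Against compound 1 the change is 6-carboxy-1H-indol-3-yl in place of 5-carboxypyridin-3-yl on a saturated chain carbon bound to an amine nitrogen in a ring. The rest of the molecule, including the saturated chain carbon bound to the ring amine nitrogen and the dichlorophenyl-bearing side chain, is unchanged. Among the measured compounds shown here, with no recorded step of this kind, the expectation rests on the change alone: a fused bicyclic carboxylic acid in place of a monocyclic one. Expected is a modest lowering of the number, a 2.3-fold lower number from compound 1 to compound 3 (0.36 log units; beyond the scatter), although an outcome within the scatter of compound 1 cannot be ruled out. Compound 3 is expected at 15000 nM, with a range from 4000 nM to 50000 nM.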

Compound 3, half-maximal effective concentration in the cGMP-dependent protein kinase 1 assay: 22000 nM
The estimate for compound 3 lay 1.5-fold (0.17 log units) below the measured number, within the range that was stated.
By their numbers in the cGMP-dependent protein kinase 1 assay, from the lowest: compound 2; then compounds 3 and 1 (each within the scatter of the next).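

In the cGMP-dependent protein kinase 1 assay, the first change read at this place, on a saturated chain carbon bound to an amine nitrogen in a ring, gives a 1.5-fold lower number from compound 1 to compound 3 (0.19 log units; within the scatter). Going from 5-carboxypyridin-3-yl, with 9 heavy atoms and one aromatic ring, to 6-carboxy-1H-indol-3-yl, with 12 heavy atoms and two aromatic rings, therefore leaves this read-out unresolved, and the two groups cannot be told apart here. In a physicochemical assay for solubility, read by HPLC, with a stated time of 24 h, at pH 7 (on this read-out higher numbers stand for higher solubility and lower numbers for lower solubility), compound 1 stands at 74000 nM and compound 3 at 128000 nM, and the same change gives a 1.7-fold higher number from compound 1 to compound 3 (0.24 log units; within the scatter), so neither read-out separates the two groups. No measurement at hand bears on why the two groups read alike.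

Both groups carry a carboxylic acid, so the compounds shown leave open whether that acid matters at this place at all; a primary amide, a methyl ester or a plain benzyl group would put this to the test. Also open, on these data alone, is whether the same near-silent swap would hold with a shorter or longer chain between the ring amine nitrogen and the aromatic acid.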